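A few compounds are considered here, and "the series" means these few. Any claim that something is new, unique, unknown or untested is made for them only; others in the source may bear on it.

Measured in an ADME assay on microsomes from liver (Mus musculus), read by LC-MS, using NADPH, with a stated time of 30 min, tested at 1 uM; a lower number here means that less of the compound is left, a higher number that more of the compound is left:
- compound 1 `C[C@H](Nc1nc(N)nc(N)c1C#N)c1cc2ccc(F)cn2c(=O)c1-c1ccccc1`: 42%
- compound 2 `Cc1cccc(-c2c([C@H](C)Nc3nc(N)nc(N)c3C#N)cc3ccc(F)cn3c2=O)c1`: < 1%

Within the data shown here, compound 1, at 42%, holds the only true number here. For compound 2, < 1% is a limit of the assay and not a number. Compound 3 `C[C@H](Nc1nc(N)nc(N)c1C#N)c1c(-c2ccccc2)c(=O)n2cc(F)ccc2c1-c1ccccc1` differs from compound 1 in one place: phenyl in place of hydrogen on an aromatic carbon. Among the measured compounds shown here, the one measured step bearing on this also replaced hydrogen on an aromatic carbon, there with methyl, and it was large: a number at least 41 percentage points lower from compound 1 to compound 2 (beyond the scatter). On these data alone, its full size stays open, as the limit of < 1% in this assay, at which 1 of the 2 values shown sits, shows. A large fall is therefore expected here too, with an expected step of a number 30 percentage points lower from compound 1 to compound 3 (beyond the scatter). For compound 3 the estimated value is 12%, with an expected range from 1% to 35%.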

Compound 3, percent of the compound remaining in the Mus musculus assay: 13%
Beside the measured number, compound 3's estimate is 1 percentage points below it, within the range that was stated.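

In the Mus musculus assay, compound 1 gives 42% and compound 3 gives 13%: phenyl on this aromatic carbon gives a number 29 percentage points lower from compound 1 to compound 3 (beyond the scatter), a step with true numbers at both ends, whose full size can therefore be read. The same change also shows a cost in a physicochemical assay for solubility (a lower number here means a less soluble compound, a higher number a more soluble compound), where compound 1 gives 691000 nM and compound 3 gives 50600 nM: it gives a 14-fold lower number from compound 1 to compound 3 (1.14 log units; beyond the scatter). The compounds shown hold only hydrogen or phenyl at this position, and they cannot tell what lies behind either fall. On these data alone, how a small amine or a carboxylic acid there would read in the Mus musculus assay and the physicochemical assay stays open.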